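The source may hold more compounds than are shown below. What is called first, only, known or untested is meant among the compounds shown, and "the series" means these compounds.

Measured so far:
Compound 1, `O=C(O)c1ccc(C(=O)/C(=C\c2ccc(F)c([N+](=O)[O-])c2)SCc2ccc(Cl)cc2Cl)cc1`: 1000 nM
Compound 2, `O=C(O)c1ccc(C(=O)/C(=C\c2ccc(F)c([N+](=O)[O-])c2)SCc2ccc(F)cc2)cc1`: 1000 nM
Compound 3, `COc1cc(OC)c(/C=C(/SCc2ccc(Cl)cc2Cl)C(=O)c2ccc(Cl)cc2)c(OC)c1`: 1000 nM

The three compounds were tested in a functional assay on DU-145 cells (Homo sapiens) for inhibition, read by trypan blue exclusion, with a stated time of 96 h; on this read-out higher numbers stand for weaker inhibition of growth and lower numbers for stronger inhibition of growth. Compound 1 gives 1000 nM, and compound 2, which differs from it by 4-fluorophenyl in place of 2,4-dichlorophenyl on a saturated chain carbon bound to a sulfur, gives 1000 nM. That single change made the step of no change at the digits printed from compound 1 to compound 2 (within the scatter), so on this read-out the change has left the growth inhibition where it was. Compound 3 carries a different core; the difference between the two cores is not broken down here. In this assay compound 3 gives 1000 nM, level with compound 1 and with compound 2.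

Compound 4, `COc1cc(OC)c(/C=C(/SCc2ccc(F)cc2)C(=O)c2ccc(Cl)cc2)c(OC)c1`, has not yet been measured. It differs from compound 3 by 4-fluorophenyl in place of 2,4-dichlorophenyl on a saturated chain carbon bound to a sulfur, the same change that was made from compound 1 to compound 2. Within the data shown here, the step expected in this assay is no change at the digits printed from compound 3 to compound 4 (within the scatter), because no change at the digits printed from compound 1 to compound 2 (within the scatter) was the outcome of the same change on the other core, and nothing among the measured compounds points to a different outcome here. Compound 4 is therefore estimated to give 1000 nM, with the expected range running from 400 nM to 2500 nM.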

Compound 4, concentration for 50% growth inhibition: 10000 nM
For compound 4 the middle estimate is 10-fold (1.00 log units) below the measured one; measured number outside the range, above it.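

In this assay, putting 4-fluorophenyl in place of 2,4-dichlorophenyl on a saturated chain carbon bound to a sulfur gave a 10-fold higher number from compound 3 to compound 4 (1.00 log units; beyond the scatter) and so weakened growth inhibition on the core of compound 3. The outcome of this change therefore did not carry from one core to the other: the same change on two cores in this assay, no change at the digits printed (within the scatter) from compound 1 to compound 2 and a 10-fold higher number (1.00 log units; beyond the scatter) from compound 3 to compound 4, 10-fold (1.00 log units) apart, beyond the scatter of two such steps. Among these compounds, this shows that, in this series, a step seen on one core cannot be assumed on the other, but it rests on only two pairs and does not show which part of the cores decides the outcome, nor what the change would do on any further core.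

The compounds shown leave open whether the two chlorines contribute separately to the difference, as no compound here carries a single chlorine on that ring. They also leave open how the two cores would respond to other groups on the sulfur, such as a longer chain or an amine.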